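This account rests on a few compounds, and the source may have more. Where it says the series, first, only, none or still open, it means among the compounds named here.

Compound 1, `COCOc1cc(/C=C/C(=O)OCC(=O)Nc2ccc(OC)cc2)ccc1OCc1ccccc1`, was tested in a functional assay on BEL-7404 cells (Homo sapiens) for cytotoxicity, read by MTT assay, with a stated time of 72 h (a higher number here means a weaker inhibitor, a lower number a stronger inhibitor), where compound 1 gives 133000 nM. Compound 2, `COc1ccc(NC(=O)COC(=O)/C=C/c2cc(OC)c(OCc3ccc(Cl)c(Cl)c3)c(OC)c2)cc1`, gives 97800 nM in this assay; of the two numbers compound 1 is the higher, yet the gap between them is within the scatter. Compound 3, `COc1ccc(NC(=O)COC(=O)/C=C/c2ccc(OCc3ccccc3)c(O)c2)cc1`, reached only the limit of the measurement and shows > 200000 nM in this assay. Compound 3 carries hydrogen in place of methoxymethyl on an oxygen on an aromatic ring, and the step of an at least 1.5-fold higher number from compound 1 to compound 3 (0.17 log units; that floor lies within the scatter) rests on (the limit of > 200000 nM in this assay, at which 1 of the 3 values shown sits), so its true size is not known.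

Compound 4, `COCOc1cc(/C=C/C(=O)OCC(=O)NCc2ccco2)ccc1OCc1ccccc1`, differs from compound 1 in one place: (furan-2-yl)methyl in place of 4-methoxyphenyl on an amide-type nitrogen. Among the measured compounds shown here, the only measured step concerns an oxygen on an aromatic ring, not the amide-type nitrogen where this exchange sits, so no measured step bears on it directly. The two numbers for compound 1 and compound 2 sit close together, and nothing here points to a shift in either direction. The expectation for compound 4 is therefore a step of a 1.1-fold higher number from compound 1 to compound 4 (0.02 log units; within the scatter) that stays within the scatter. Compound 4 is estimated at 140000 nM in this assay, with a range from 55000 nM to 350000 nM.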

Compound 4, half-maximal inhibitory concentration: > 200000 nM
Compound 4 was reported as a limit; the forecaster's own chance of this, stated with the estimate: 30%; middle value at least 1.4-fold (0.15 log units) away from the limit.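

Among the compounds shown here, this is the first measured change at the amide-type nitrogen, and in this assay putting (furan-2-yl)methyl in place of 4-methoxyphenyl gives an at least 1.5-fold higher number from compound 1 to compound 4 (0.17 log units; that floor lies within the scatter). Compound 4 gives > 200000 nM, which is a limit of the assay and not a number. The exchange therefore gives no sign of a stronger inhibitor at this position, but the printed floor lies within the scatter, so the result does not establish a real weakening, and the true size of the step remains unknown: the limit of > 200000 nM in this assay, at which 2 of the 4 values shown sit.

The change replaces a six-membered aromatic ring of carbon only with a five-membered aromatic ring with a hetero atom, and it also adds a methyl link to the nitrogen, so the compounds shown do not separate these two parts; a benzyl group on this nitrogen would keep the six-membered ring together with the link. They also leave open how this position would read with a non-aromatic group, such as a butyl chain, a 2-aminoethyl chain or a chain ending in a carboxylic acid.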